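The compounds below may be only part of what the source reports. "The series", "measured", "known", "first", "only" and "open" are said of these compounds alone.

Measured compounds in a toxicity assay on GES1 cells (Homo sapiens) for inhibition, read by MTT assay, with a stated time of 72 h; on this read-out lower numbers stand for stronger inhibition and higher numbers for weaker inhibition:
- compound 1, `Cc1cc(N2CC[C@@H](C)[C@@H](N(C)c3ncnc4[nH]ccc34)C2)n2nc(SCc3ccc(C(F)(F)F)cc3)nc2n1`: 17300 nM
- compound 2, `Cc1cc(N2CC[C@@H](C)[C@@H](N(C)c3ncnc4[nH]ccc34)C2)n2nc(SCC3CC3)nc2n1`: 27900 nM
- compound 3, `Cc1cc(N2CC[C@@H](C)[C@@H](N(C)c3ncnc4[nH]ccc34)C2)n2nc(SCc3ccc(Br)cc3)nc2n1`: 55600 nM

Compound 2 stands second highest of the three numbers in this assay; its nearest neighbour is compound 1 (a 1.6-fold higher number from compound 1 to compound 2 (0.21 log units; within the scatter)), its furthest is compound 3 (a 2.0-fold higher number from compound 2 to compound 3 (0.30 log units; within the scatter)), and both gaps lie within the scatter, so no order among the three can be read from them.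

Compound 4, `Cc1ccc(CSc2nc3nc(C)cc(N4CC[C@@H](C)[C@@H](N(C)c5ncnc6[nH]ccc56)C4)n3n2)cc1`, is not yet measured. It differs from compound 2 in one place: 4-methylphenyl in place of cyclopropyl on a saturated chain carbon bound to a sulfur. Read one bond further out, the change is (cyclopropylmethyl)sulfanyl to (4-methylbenzyl)sulfanyl.

Going by the values given here, two measured steps bear on this. The step from 4-(trifluoromethyl)phenyl to cyclopropyl at the same place (a 1.6-fold higher number from compound 1 to compound 2 (0.21 log units; within the scatter)) and the step from cyclopropyl to 4-bromophenyl (a 2.0-fold higher number from compound 2 to compound 3 (0.30 log units; within the scatter)) both stayed within the scatter. Swapping the cyclopropyl for a substituted phenyl on this carbon has therefore not moved the number beyond the scatter in either direction among the three compounds shown, though the same holds only for these two phenyl substituents.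

For compound 4 the expectation is accordingly a step of about a 1.1-fold higher number from compound 2 to compound 4 (0.06 log units; within the scatter) in this assay, that is, no change beyond the scatter. Compound 4 is estimated at 32000 nM, with a range of 13000 nM to 75000 nM in this assay.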

Compound 4, half-maximal inhibitory concentration: 82500 nM
Compound 4: middle estimate off by 2.6-fold (0.41 log units), on the low side, and the stated range ends below it.
By their numbers in this assay, from the lowest: compounds 1, 2, 3 and 4 (each within the scatter of the next, the first and the last beyond it).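

In this assay the 4-methylphenyl group gives the first step from cyclopropyl beyond the scatter at this saturated chain carbon bound to a sulfur (a 3.0-fold higher number from compound 2 to compound 4 (0.47 log units; beyond the scatter)), so a substituted phenyl here can shift the number beyond the scatter. The substituent on the aromatic carbon also counts: methyl in place of trifluoromethyl gives a step beyond the scatter (a 4.8-fold higher number from compound 1 to compound 4 (0.68 log units; beyond the scatter)), whereas methyl in place of bromo stays within it (a 1.5-fold higher number from compound 3 to compound 4 (0.17 log units; within the scatter)), leaving compound 1 apart from both compound 3 and compound 4. No available evidence bears on the reason for this result.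

Open, as far as these compounds go, is where an unsubstituted phenyl, a methoxy group or a carboxylic acid on the aromatic carbon would fall. Also open, from the compounds shown here alone, is whether a longer chain in place of cyclopropylmethyl would stay near compound 2.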